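The source may hold more compounds than are shown below. What is called first, only, known or untested is meant among the compounds shown, and "the series" means these compounds.

Compound 1 `Cc1cccc(-n2nncc2CN2C(=O)C3(C(C#N)=C(N)Oc4c(N)cc5nc6ccccc6nc5c43)c3ccccc32)c1` gives in a functional assay on HCT-116 cells (Homo sapiens) for antiproliferative activity, read by MTT assay, with a stated time of 48 h (on this read-out higher numbers stand for weaker inhibition and lower numbers for stronger inhibition), only a limit, > 50000 nM.
Compound 2 `N#CC1=C(N)Oc2c(N)cc3nc4ccccc4nc3c2C12C(=O)N(Cc1cnnn1-c1ccccc1Br)c1ccccc12` gives in this assay 12400 nM.
Compound 3 `N#CC1=C(N)Oc2c(N)cc3nc4ccccc4nc3c2C12C(=O)N(Cc1cnnn1-c1c(F)cccc1F)c1ccccc12` gives in this assay only a limit, > 50000 nM.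

Compound 3 therefore stands at the limit of this assay, where two of the three values sit (the limit of > 50000 nM in this assay, at which 2 of the 3 values shown sit). Compound 4 `N#CC1=C(N)Oc2c(N)cc3nc4ccccc4nc3c2C12C(=O)N(Cc1cnnn1-c1ccc(F)c(Cl)c1)c1ccccc12` differs from it by 3-chloro-4-fluorophenyl in place of 2,6-difluorophenyl on an aromatic nitrogen. The nearest measured step is an at least 4.0-fold higher number from compound 2 to compound 3 (0.60 log units; beyond the scatter), which shows that swapping the group on this aromatic nitrogen can shift the number beyond the scatter; the step that the two limits leave unreadable from compound 1 to compound 3 stays unreadable. Going by the values given here, no measured step points in a direction for this new group, so the step expected is an at least 1.6-fold lower number from compound 3 to compound 4 (0.22 log units; that floor lies within the scatter), uncertain in size. Compound 4 is estimated at 30000 nM, within 8000 nM to 60000 nM.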

Compound 4, half-maximal inhibitory concentration: > 50000 nM
Compound 4: a limit, no number; the forecaster's own chance of this, stated with the estimate: 45%; middle value at least 1.6-fold (0.22 log units) from the limit.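

In this assay compound 4 gives > 50000 nM, which is a limit and not a number. Putting 3-chloro-4-fluorophenyl in place of 2-bromophenyl on this aromatic nitrogen gives an at least 4.0-fold higher number from compound 2 to compound 4 (0.60 log units; beyond the scatter), while the steps among the compounds at the limit cannot be read. Compound 2, with its 2-bromophenyl, remains the only compound here with a measured number, and the others all rest at one ceiling: the limit of > 50000 nM in this assay, at which 3 of the 4 values shown sit.

Still open, from the compounds shown here alone, is whether an unsubstituted phenyl, a phenyl carrying an amine or a carboxylic acid, or a longer alkyl chain in place of the ring would give a readable number at this position.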